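This account rests on a few compounds, and the source may have more. Where it says the series, first, only, none or still open, it means among the compounds named here.

Compound 1 `CCOC(=O)c1oc2ccc(N(Cc3ccccc3)S(=O)(=O)c3ccc(Br)cc3)cc2c1C` carries a 4-bromophenyl on a sulfonyl sulfur. For the measured compounds named here, in a functional assay on HCT-116 cells (Homo sapiens) for inhibition, read by MTT assay, with a stated time of 72 h (on this read-out lower numbers stand for stronger inhibition and higher numbers for weaker inhibition), compound 1 gives 8700 nM, the only actual number among the three values shown. Compound 2 `CCOC(=O)c1oc2ccc(N(Cc3ccccc3)S(=O)(=O)c3cccc(Br)c3)cc2c1C` has 3-bromophenyl in place of 4-bromophenyl on a sulfonyl sulfur. In this assay compound 2 reaches only a limit of the assay, > 40000 nM. Compound 3 `CCOC(=O)c1oc2ccc(N(Cc3ccccc3)S(=O)(=O)c3ccc(C)cc3)cc2c1C` has methyl in place of bromo on an aromatic carbon. In this assay compound 3 likewise reaches only a limit of the assay, > 40000 nM. The two measured steps away from compound 1 are an at least 4.5-fold higher number from compound 1 to compound 2 (0.66 log units; beyond the scatter) and an at least 4.5-fold higher number from compound 1 to compound 3 (0.66 log units; beyond the scatter); the remaining comparison is a step that the two limits leave unreadable from compound 2 to compound 3 because of the limit of > 40000 nM in this assay, at which 2 of the 3 values shown sit.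

Compound 4 `CCOC(=O)c1oc2ccc(N(Cc3ccccc3)S(=O)(=O)c3ccccc3)cc2c1C` differs from compound 1 as follows: hydrogen in place of bromo on an aromatic carbon. Both measured changes at the 4-bromophenyl weakened inhibition beyond the scatter, and removing the bromo is a third change at the same place. Compound 4 is therefore expected to show a step of a 4.6-fold higher number from compound 1 to compound 4 (0.66 log units; beyond the scatter), toward weaker inhibition. Compound 4 is estimated at 40000 nM, with a range from 15000 nM to 100000 nM, and it may well return only a limit rather than a number.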

Compound 4, half-maximal inhibitory concentration: > 40000 nM
Compound 4 was reported as a limit; the forecaster's own chance of this, stated with the estimate: 60%; the middle value lies on the limit itself.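

The step of an at least 4.5-fold higher number from compound 1 to compound 4 (0.66 log units; beyond the scatter) shows that in this assay the measurable inhibition of compound 1 depends on the bromo itself, since the plain phenylsulfonyl group, with nothing at that place, no longer gives a number. The earlier compounds shown here showed only that moving the bromo or replacing it with methyl cost inhibition, which left open whether those two groups simply did harm; with hydrogen in the same place that reading falls away, and among the four compounds only the 4-bromophenyl gives a number. How compound 2, compound 3 and compound 4 rank against one another cannot be read, because all three stand at the same limit of the assay: the limit of > 40000 nM in this assay, at which 3 of the 4 values shown sit.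

The compounds shown leave open whether another halogen, such as chloro or iodo, or a group such as methoxy or trifluoromethyl at the same place would keep a measurable number, or go beyond that of compound 1. They also leave open whether changes elsewhere on the core of compound 1, such as a carboxylic acid in place of the ethyl ester, would alter this dependence on the bromo.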